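From compound 2 to a bare aromatic carbon

A few compounds are considered here, and "the series" means these few. Any claim that something is new, unique, unknown or untested is made for them only; others in the source may bear on it.

Measured in a functional assay on NCI-H1581 cells (Homo sapiens) for antiproliferative activity, read by CCK-8 assay, with a stated time of 72 h; a lower number here means a stronger inhibitor, a higher number a weaker inhibitor:
- compound 1 `COc1cc(OC)c(Cl)c(-c2ccc3c(NC(=O)c4ccc(N5CCN(C(C)=O)CC5)cc4)n[nH]c3n2)c1Cl`: 43.3 nM
- compound 2 `COc1cc(OC)c(Cl)c(-c2ccc3c(NC(=O)c4ccc(N5CCN(S(C)(=O)=O)CC5)cc4)n[nH]c3n2)c1Cl`: 245 nM

Of the two, compound 2 carries the higher number and is the weaker inhibitor. Among the compounds with values here, the only measured step, a 5.7-fold higher number from compound 1 to compound 2 (0.75 log units; beyond the scatter), places methylsulfonyl in place of acetyl on an amine nitrogen in a ring. Compound 3 `COc1cc(OC)c(Cl)c(-c2ccc3c(NC(=O)c4ccccc4)n[nH]c3n2)c1Cl` goes further, with hydrogen in place of 4-(methylsulfonyl)piperazin-1-yl on an aromatic carbon as its change, so the whole group is lost rather than just its end. Within the data shown here, no measured compound shows such a loss, which leaves that one modest step as the only guide. A further modest rise in the number is therefore expected, though with wide uncertainty. The expected change is a 2.9-fold higher number from compound 2 to compound 3 (0.46 log units; beyond the scatter) by this estimate. Compound 3 is estimated at 700 nM in this assay with an expected range from 150 nM to 3500 nM as its span.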

Compound 3, half-maximal inhibitory concentration: > 1000 nM
Compound 3 ended at the assay's limit; the forecaster's own chance of this, stated with the estimate: 15%; at least 1.4-fold (0.15 log units) between middle value and limit.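

In this assay compound 3 gives > 1000 nM, which is a limit of the assay and not a number. Replacing the whole 4-(methylsulfonyl)piperazin-1-yl group with hydrogen gives an at least 4.0-fold higher number from compound 2 to compound 3 (0.61 log units; beyond the scatter), and replacing the 4-acetylpiperazin-1-yl group with hydrogen gives an at least 23-fold higher number from compound 1 to compound 3 (1.36 log units; beyond the scatter), so both steps are lower bounds. The earlier step showed only that the end of the group matters, whereas these show that a bare aromatic carbon at this place, para to a large group, is worse than either substituted piperazine.

From the compounds shown here alone, it remains open how much of the difference belongs to the piperazine ring itself, since a free secondary amine on that ring would separate the ring from its end group. A morpholine or a small methoxy group at this carbon would also show how much of the group is needed.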